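This account rests on a few compounds, and the source may have more. Where it says the series, first, only, none or still open, it means among the compounds named here.

Values in an ADME assay on HEK-293T cells (Homo sapiens) for cytotoxicity, read by MTT assay, with a stated time of 48 h; a higher number here means that more compound is tolerated, a lower number that less compound is tolerated:
compound 1 `Cn1cc(C2CC(c3ccccc3)=NN2C(=O)c2cccnc2)c2ccccc21`: > 300000 nM (a limit)
compound 2 `Cc1ccc(C(=O)N2N=C(c3ccccc3)CC2c2cn(C)c3ccccc23)cn1`: 154000 nM
compound 3 `Cn1cc(C2CC(c3ccccc3)=NN2C(=O)c2cccnc2Cl)c2ccccc21`: > 300000 nM (a limit)

Compound 1 is known only through a limit and not through a number, and it stands at the limit of > 300000 nM in this assay, at which 2 of the 3 values shown sit.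

Compound 4 `COc1ccc2c(c1)c(C1CC(c3ccccc3)=NN1C(=O)c1cccnc1)cn2C` has not yet been measured. It differs from compound 1 by methoxy in place of hydrogen on an aromatic carbon.

Two measured steps are of a similar kind, though neither falls on the ring that takes the methoxy. Methyl in place of hydrogen on an aromatic carbon gave an at least 1.9-fold lower number from compound 1 to compound 2 (0.28 log units; that floor lies within the scatter). Adding a chloro group gave a step that the two limits leave unreadable from compound 1 to compound 3. Neither step shows a change beyond the scatter, so none is expected in this assay for the methoxy, though any shift would more likely be toward a lower number, as the methyl step allows. The expected change is an at least 1.2-fold lower number from compound 1 to compound 4 (0.07 log units; that floor lies within the scatter). A report of only a limit would be no surprise.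

For compound 4 the estimate is 250000 nM, with an expected range from 100000 nM to 500000 nM.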

Compound 4, half-maximal cytotoxic concentration: > 300000 nM
Compound 4: only a limit was reported; the forecaster's own chance of this, stated with the estimate: 50%; middle value at least 1.2-fold (0.07 log units) away from the limit.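

In this assay compound 4 gives > 300000 nM, which is a limit and not a number. Compound 1 is also known only through a limit, and the step from compound 1 to compound 4 cannot be read. The compounds shown leave open whether methoxy in place of hydrogen changes the tolerated concentration at all in this assay.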